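A Small Exchange on the Aryl Group of Compound 3

This account rests on a few compounds, and the source may have more. Where it says the series, first, only, none or still open, it means among the compounds named here.

Three related compounds have been tested so far in a functional assay on A549 cells (Homo sapiens) for antiproliferative activity, read by MTT assay, with a stated time of 72 h; a lower number here means a stronger inhibitor, a higher number a weaker inhibitor. Compound 1 `COc1cc2ncnc(Nc3cccc(Cl)c3)c2cc1OCCCN1CCNCCNCCNCC1` gives 27100 nM. Compound 3 `COc1cc2ncnc(Nc3ccc(F)c(Br)c3)c2cc1OCCCN1CCNCCNCC1` gives 34300 nM, which lies within the usual scatter of the number for compound 1. Compound 2 `C#Cc1cccc(Nc2ncnc3cc(OC)c(OCCCN4CCNCCNCC4)cc23)c1` returns no number, only a limit of the assay: > 50000 nM.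

Compound 4 `COc1cc2ncnc(Nc3cccc(Cl)c3)c2cc1OCCCN1CCNCCNCC1` has not yet been measured. It differs from compound 3 by one exchange on a nitrogen on an aromatic ring: 3-chlorophenyl in place of 3-bromo-4-fluorophenyl on a nitrogen on an aromatic ring. For the measured compounds named here, the one measured step that alters the group at this place is an at least 1.4-fold lower number from compound 2 to compound 3 (0.16 log units; that floor lies within the scatter). That figure is only a floor, and it lies within the scatter, so it gives no firm sign that this group moves the number.

No shift beyond the scatter is therefore expected in this assay, and the estimated step is a 1.1-fold lower number from compound 3 to compound 4 (0.06 log units; within the scatter). Compound 4 is expected at about 30000 nM, with an estimated range of 16000 nM to 50000 nM.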

Compound 4, half-maximal inhibitory concentration: > 50000 nM
Compound 4 was reported as a limit; the forecaster's own chance of this, stated with the estimate: 15%; middle value at least 1.6-fold (0.22 log units) away from the limit.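

In this assay, the exchange on this nitrogen gives an at least 1.4-fold higher number from compound 3 to compound 4 (0.16 log units; that floor lies within the scatter), and compound 4 yields only a limit of the assay, not a number. For the compounds shown here, compound 4 also gives the first pair that shares 3-chlorophenyl and differs only in the ring on the chain, with the nine-membered ring in place of a larger ring: an at least 1.8-fold higher number from compound 1 to compound 4 (0.26 log units; that floor lies within the scatter). Both steps are floors only, and the step between compound 2 and compound 4 cannot be read, as both are limits: the limit of > 50000 nM in this assay, at which 2 of the 4 values shown sit.

On these data alone, whether either exchange truly moves the number beyond the scatter stays open. Also open, as far as these compounds go, is how an amine in place of the chloro group, or a longer chain carrying the nine-membered ring, would change the result.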